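The compounds below may be only part of what the source reports. "The series", "measured", "known", "first", "only" and "open" are said of these compounds alone.

In an ADME assay on L1210/0 cells (Mus musculus) for cytotoxicity, with a stated time of 48 h (on this read-out higher numbers stand for weaker inhibition and lower numbers for stronger inhibition), compound 1 (`Cc1ccc(C(=O)/C=C/c2cc(=O)[nH]c(=O)n2COCCO)cc1`) gives 27900 nM while compound 2 (`O=C1O/C(=C\Cn2cc(C(F)(F)F)c(=O)[nH]c2=O)C(OCc2ccccc2)=C1OCc1ccccc1`) gives 2000 nM as the lower of the two numbers, a gap beyond the scatter. Compound 3 (`O=C1O/C(=C\Cn2cc(I)c(=O)[nH]c2=O)C(OCc2ccccc2)=C1OCc1ccccc1`) carries iodo in place of trifluoromethyl on an aromatic carbon. Among the compounds with values here, no step between measured compounds differing in one place is available, so the expectation rests on compound 2 at 2000 nM alone. Expected is a 1.5-fold higher number from compound 2 to compound 3 (0.18 log units; within the scatter) in this assay as a small move to a higher number, not beyond the scatter. For compound 3 the estimated value is 3000 nM with an expected range from 1000 nM to 9000 nM in this series.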

Compound 3, half-maximal inhibitory concentration: 7500 nM
For compound 3 the middle estimate is 2.5-fold (0.40 log units) below the measured one; the measured number falls inside the stated range.
By their numbers in this assay, from the lowest: compound 2; then compound 3; then compound 1.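

At this aromatic carbon of the shared core, the substituent matters in this assay: iodo in place of trifluoromethyl gives a 3.8-fold higher number from compound 2 to compound 3 (0.57 log units; beyond the scatter). Within the data shown here, this is the first comparison that differs in one place, and at this position it favours trifluoromethyl over iodo. No measured property is available to account for this step.

As far as these compounds go, whether a nitrile or an amine at this carbon would give a lower or higher number remains open. So does whether the step would hold on a core other than that of compound 2.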